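Bromo for chloro beside the carbamate: a second pair

The source may report more compounds than this note shows. Statements on the series, on what has been measured and on what is new or still open speak of the compounds shown alone.

Three compounds of the series are measured, one is not. Compound 1 `O=C(NCCCCl)Oc1ccc(Cl)cc1C(=O)Nc1ccc(C(F)(F)F)cc1` is the starting point. In an ADME assay on MONO-MAC-6 cells (Homo sapiens) for cytotoxicity, read by MTT assay, with a stated time of 16 h (a lower number here means a stronger inhibitor, a higher number a weaker inhibitor), compound 1 gives 8800 nM. Compound 3 `O=C(NCCCCl)Oc1ccc(Br)cc1C(=O)Nc1ccc(C(F)(F)F)cc1` differs from compound 1 in a single place: bromo in place of chloro on an aromatic carbon In this assay the change produced a 1.5-fold lower number from compound 1 to compound 3 (0.19 log units; within the scatter), so the two compounds cannot be separated on this measurement.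

Compound 2 `O=C(NCCCCl)Oc1ccc(Cl)cc1C(=O)Nc1ccc(Cl)c(Cl)c1` is built on a different core; the difference between the core of compound 1 and the core of compound 2 is not broken down here. In this assay compound 2 gives 2500 nM, the lowest of the three numbers, with compound 3 at 5700 nM as its nearest neighbour and compound 1 furthest away, both gaps lying beyond the scatter.

Compound 4 `O=C(NCCCCl)Oc1ccc(Br)cc1C(=O)Nc1ccc(Cl)c(Cl)c1` has not been measured. It stands to compound 2 exactly as compound 3 stands to compound 1: bromo in place of chloro on an aromatic carbon The surroundings of the exchanged atom are described in identical words for both pairs, so this is the same change made on a second core. Among the measured compounds shown here, the only guide to its effect is the pair compound 1 to compound 3, and there the step stayed within the scatter. The step from compound 2 to compound 4 in this assay is therefore expected to be small, a 1.4-fold lower number from compound 2 to compound 4 (0.14 log units; within the scatter), resting on a 1.5-fold lower number from compound 1 to compound 3 (0.19 log units; within the scatter). For compound 4 the estimate in this assay is 1800 nM, within a range from 900 nM to 3600 nM. Whether the second core carries the change the same way remains to be seen.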

Compound 4, half-maximal inhibitory concentration: 9500 nM
Estimate against measurement, compound 4: 5.3-fold (0.72 log units) below, outside the stated range (above it).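

In this assay, bromo in place of chloro on an aromatic carbon, meta to a large group and para to a ((3-chloropropyl)carbamoyl)oxy group, gives a 3.8-fold higher number from compound 2 to compound 4 (0.58 log units; beyond the scatter), so on this core the exchange registers as a real step, and a modest one. The exchange therefore does not carry over as a constant increment between the two cores, and a step read on one core is a poor guide to the step on the other: the same change on two cores in this assay, a 1.5-fold lower number (0.19 log units; within the scatter) from compound 1 to compound 3 and a 3.8-fold higher number (0.58 log units; beyond the scatter) from compound 2 to compound 4, 5.9-fold (0.77 log units) apart, beyond the scatter of two such steps

Among the compounds shown here, this does not show that the exchange behaves differently on every core, as the comparison rests on only two pairs, and it does not identify what in the cores produces the gap, whether the trifluoromethyl group of compound 1, the chloro groups of compound 2 or something else, so no cause can be assigned.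

The compounds shown leave open how a fluoro or methoxy group, or an amine, at the same aromatic carbon would compare with chloro and bromo on either core. They also leave open whether the gap between the cores would persist with a longer chain in place of the 3-chloropropyl group on the carbamate.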